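The source may hold more compounds than are shown below. What is called first, only, known or untested is meant among the compounds shown, and "the series" means these compounds.

Measured in a physicochemical assay for solubility, read by HPLC, in phosphate buffer, at pH 6.5; a lower number here means a less soluble compound, a higher number a more soluble compound:
- Compound 1 `COC(=O)C1=C(C)NC(c2nccs2)=NC1(C)c1ccc(F)cc1`: 22 ug/mL
- Compound 2 `COC(=O)C1=C(CN2CCCCC2)NC(c2nccs2)=NC1(C)c1ccc(F)cc1`: 282 ug/mL

Compound 2 stands higher of the two. Going by the values given here, the one measured step, large and beyond the scatter, is a 13-fold higher number from compound 1 to compound 2 (1.11 log units; beyond the scatter). Among the compounds with values here, that step put piperidin-1-yl in place of hydrogen, and no measured step exchanges one ring for another. Compound 3 `COC(=O)C1=C(CN2CCNCC2)NC(c2nccs2)=NC1(C)c1ccc(F)cc1` carries piperazin-1-yl in place of piperidin-1-yl on a saturated chain carbon bound to a double-bonded ring carbon. The measured step bears on this only indirectly, so in this assay a small upward step, perhaps none beyond the scatter, is expected. The expected change is a 1.2-fold higher number from compound 2 to compound 3 (0.09 log units; within the scatter). For compound 3 the estimated value is 350 ug/mL, with an expected range of 120 ug/mL to 1000 ug/mL.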

Compound 3, solubility: 250 ug/mL
Estimate against measurement, compound 3: 1.4-fold (0.15 log units) above, and the stated range covers the measured number.
By their numbers in this assay, from the lowest: compound 1; then compounds 3 and 2 (each within the scatter of the next).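

In this assay, going by these compounds alone, the first ring exchange at this position gives a 1.1-fold lower number from compound 2 to compound 3 (0.05 log units; within the scatter), so piperazin-1-yl and piperidin-1-yl cannot be told apart here. Piperazin-1-yl in place of hydrogen gives an 11-fold higher number from compound 1 to compound 3 (1.06 log units; beyond the scatter), so the large gain is not confined to piperidin-1-yl. Nothing available explains this result.

The compounds shown leave open whether morpholin-4-yl or an open-chain amine such as dimethylamino would give a similar number at this place. They also leave open how a carboxylic acid there would compare.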